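Amide aryl variants on a shared flavonol core

The source may report more compounds than this note shows. Statements on the series, on what has been measured and on what is new or still open speak of the compounds shown alone.

Compound 1 `COc1ccc(C(=O)Nc2cccc(-c3oc4cc(-c5ccc(F)cc5)ccc4c(=O)c3O)c2)cc1`: 5490 nM
Compound 2 `CCc1ccc(C(=O)Nc2cccc(-c3oc4cc(-c5ccc(F)cc5)ccc4c(=O)c3O)c2)cc1`: 13200 nM
Compound 3 `Cc1cc(C(=O)Nc2cccc(-c3oc4cc(-c5ccc(F)cc5)ccc4c(=O)c3O)c2)ccc1F`: 5420 nM

In a functional assay on HCC1937 cells (Homo sapiens) for antiproliferative activity, read by CCK-8 assay, with a stated time of 72 h (a lower number here means a stronger inhibitor, a higher number a weaker inhibitor), compound 3 gives the lowest of the three numbers, though the step of a 1.0-fold lower number from compound 1 to compound 3 (0.01 log units; within the scatter) lies within the scatter; only compound 2 stands apart, a 2.4-fold lower number from compound 2 to compound 3 (0.39 log units; beyond the scatter). Compound 4 `COc1ccc(C(=O)Nc2cccc(-c3oc4cc(-c5ccc(F)cc5)ccc4c(=O)c3O)c2)c(F)c1` carries the change (2-fluoro-4-methoxyphenyl in place of 4-fluoro-3-methylphenyl on a carbonyl carbon). Going by the values given here, no measured step is an exact precedent. Compound 1 holds the 4-methoxyphenyl and is indistinguishable from compound 3 in this assay; compound 2 shows that a change on this aryl can shift the number, a 2.4-fold higher number from compound 1 to compound 2 (0.38 log units; beyond the scatter). Among the compounds with values here, the added fluorine has no counterpart among the steps, so the expected shift for compound 4 is a 1.0-fold higher number from compound 3 to compound 4 (0.01 log units; within the scatter), none beyond the scatter. Compound 4 is estimated at 5500 nM, between 2500 nM and 12000 nM.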

Compound 4, half-maximal inhibitory concentration: 24500 nM
Compound 4: the middle estimate sits 4.5-fold (0.65 log units) below what was measured; the measured number lies above the stated range.
By their numbers in this assay, from the lowest: compounds 3 and 1 (each within the scatter of the next); then compounds 2 and 4 (each within the scatter of the next).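

In this assay, going by these compounds alone, fluoro in place of hydrogen on the 4-methoxyphenyl aryl gives a 4.5-fold higher number from compound 1 to compound 4 (0.65 log units; beyond the scatter) and is the only single-atom change, so a small addition on this aryl can cost more than the earlier steps showed. The swap from 4-fluoro-3-methylphenyl gives a 4.5-fold higher number from compound 3 to compound 4 (0.66 log units; beyond the scatter) as its step, while a 1.9-fold higher number from compound 2 to compound 4 (0.27 log units; within the scatter) allows no order between those two amides, which together stand apart from the other pair. No measurement on hand bears on the reason for this shift.

From the compounds shown here alone, whether the loss is specific to fluoro on this aryl stays open. Chloro, hydroxy or dimethylamino in that place would test it.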